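The source may report more compounds than this note shows. Statements on the series, on what has been measured and on what is new or still open speak of the compounds shown alone.

Compound 1 `CCCCSc1nsnc1[C@@H]1CN2CCC[C@H]1C2`: in a functional assay on the whole organism with Mus musculus as the target (a lower number here means that less compound is needed, a higher number that more compound is needed for the effect), compound 1 gives > 3 mg/kg, a limit of the assay.
Compound 2 `CCCCSc1nsnc1[C@H]1CN2CCC[C@@H]1C2`: compound 2 gives > 0.3 mg/kg, also a limit.
Compound 3 `CCCSc1nsnc1[C@H]1CN2CCC[C@@H]1C2`: compound 3 gives 2.2 mg/kg.

Among the compounds with values here, compound 3 thus holds the only real number here; the other two values are limits. Compound 4 `CCCSc1nsnc1[C@@H]1CN2CCC[C@H]1C2` differs from compound 3 by the two compounds have the same atoms and bonds; at least one stereo element is drawn with a configuration in one of them and without one in the other: 2 of 3 stereo elements differ; a stereocentre at a saturated ring carbon is drawn R in compound 3 and S in compound 4; a stereocentre at a saturated ring carbon is drawn S in compound 3 and R in compound 4. The same kind of change separates compound 1 from compound 2, but that step, a step that the two limits leave unreadable from compound 1 to compound 2, cannot be read because the limit of > 0.3 mg/kg in this assay, at which 1 of the 3 values shown sits, and the limit of > 3 mg/kg in this assay, at which 1 of the 3 values shown sits, bound it from one side only. The step that the limit leaves unreadable from compound 2 to compound 3 is unreadable as well. Compound 4 shares its drawn configuration with compound 1, and because the limit of > 3 mg/kg in this assay, at which 1 of the 3 values shown sits, sits on that configuration, more compound is expected to be needed. Compound 4 is expected at 6 mg/kg, between 1.5 mg/kg and 30 mg/kg. The expected step is a 2.7-fold higher number from compound 3 to compound 4 (0.44 log units; beyond the scatter).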

Compound 4, dose for half-maximal effect: 1.3 mg/kg
Estimate against measurement, compound 4: 4.6-fold (0.66 log units) above, outside the stated range (below it).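

Within the data shown here, with the chain on sulfur held constant, the swap of configuration at the two saturated ring carbons can now be read for the first time: a 1.7-fold lower number from compound 3 to compound 4 (0.23 log units; within the scatter), so in this assay this pair shows no separation between the two configurations. The change of hydrogen in place of methyl on the chain also becomes readable: an at least 2.3-fold lower number from compound 1 to compound 4 (0.36 log units; beyond the scatter). Compound 1 gives > 3 mg/kg, a limit.

From the compounds shown here alone, the steps from compound 1 to compound 2 and from compound 2 to compound 3 cannot be read, so whether configuration matters with the longer of these chains stays open. Going by these compounds, how a hexyl chain or a chain ending in a carboxylic acid would behave on the sulfur also remains open.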